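The source may hold more compounds than are shown below. What is called first, only, known or untested is meant among the compounds shown, and "the series" means these compounds.

Compound 1 `Nc1nc(N)c2c(-c3cc4ccccc4o3)cn([C@@H]3O[C@H](CO)[C@@H](O)[C@H]3O)c2n1`: > 20000 nM
Compound 2 `COc1ncnc2c1c(I)cn2[C@@H]1O[C@H](CO)[C@@H](O)[C@H]1O`: 14300 nM

In a functional assay on HeLa S3 cells (Homo sapiens) for antiproliferative activity, read by XTT assay, with a stated time of 72 h (a lower number here means a stronger inhibitor, a higher number a weaker inhibitor), compound 2 gives 14300 nM, the only number among the results shown. Compound 1 reaches only the limit of > 20000 nM in this assay, at which 1 of the 2 values shown sits, and is not a number. Compound 3 `COc1ncnc2c1c(-c1cc3ccccc3o1)cn2[C@@H]1O[C@H](CO)[C@@H](O)[C@H]1O` differs from compound 2 by 1-benzofuran-2-yl in place of iodo on an aromatic carbon. Within the data shown here, no measured pair differs in just this way, so no measured step sets the size. A small move toward weaker inhibition, not beyond the scatter, is expected for compound 3, due to the limit of > 20000 nM in this assay, at which 1 of the 2 values shown sits, seen for compound 1, which carries the same 1-benzofuran-2-yl group on another core. For compound 3 the estimate is 20000 nM, within 5000 nM to 60000 nM, a step of a 1.4-fold higher number from compound 2 to compound 3 (0.15 log units; within the scatter).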

Compound 3, half-maximal inhibitory concentration: 9240 nM
For compound 3 the middle estimate is 2.2-fold (0.34 log units) above the measured one; the range from low to high includes it.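

In this assay, replacing the single iodo atom with 1-benzofuran-2-yl, a group of 9 heavy atoms and two aromatic rings, gives a 1.5-fold lower number from compound 2 to compound 3 (0.19 log units; within the scatter) at this aromatic carbon. Among these compounds, a far larger group therefore leaves the reading within the scatter, which no earlier pair could show. Nothing measured here gives a cause for this result.

Going by these compounds, whether an amine or a carboxylic acid on this same carbon would shift the reading beyond the scatter stays open. So does the reading of a simple phenyl ring there.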